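A longer chain on compound 2

This account rests on a few compounds, and the source may have more. Where it says the series, first, only, none or still open, it means among the compounds named here.

Compound 1 `CCCCCCC[C@@H](CCO)n1cnc2c(Cl)ncnc21` gives 10700 nM
Compound 2 `CCCCCCC[C@H](CCO)n1cnc2c(Cl)ncnc21` gives 2670 nM

In a functional assay on HCT-116 cells (Homo sapiens) for antiproliferative activity, read by MTT assay, with a stated time of 48 h (a higher number here means a weaker inhibitor, a lower number a stronger inhibitor), compound 2 has the lower number of the pair, at 2670 nM, which makes it the stronger inhibitor. For the measured compounds named here, the only measured step, a 4.0-fold lower number from compound 1 to compound 2 (0.60 log units; beyond the scatter), comes with the fact that compounds 1 and 2 differ only in the configuration as drawn, so it says nothing direct about chain length. Compound 3 `CCCCCCCCC[C@H](CCO)n1cnc2c(Cl)ncnc21` differs from compound 2 by ethyl in place of hydrogen on a saturated chain carbon, eight bonds along the chain from an aromatic nitrogen. Going by the values given here, no measured step touches the chain, so no shift beyond the scatter is expected. The estimated change is a 1.3-fold lower number from compound 2 to compound 3 (0.13 log units; within the scatter) for now. Compound 3 is expected at 2000 nM, with an estimated range of 750 nM to 6000 nM.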

Compound 3, half-maximal inhibitory concentration: 450 nM
For compound 3 the middle estimate is 4.4-fold (0.65 log units) above the measured one, and the stated range ends above it.
By their numbers in this assay, from the lowest: compound 3; then compound 2; then compound 1.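

In this assay, the saturated chain carbon eight bonds along the chain from an aromatic nitrogen proves sensitive to change: ethyl in place of hydrogen there gives a 5.9-fold lower number from compound 2 to compound 3 (0.77 log units; beyond the scatter). For the compounds shown here, the only earlier step concerned configuration, so this is the first sign that chain length itself matters, though it rests on this single pair.

From the compounds shown here alone, whether a longer chain or a phenyl group at this place would lower the number further remains open, as does the effect of ethyl in the configuration of compound 1. Nothing measured here bears on the reason for this step.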